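The source may hold more compounds than are shown below. What is called first, only, known or untested is meant among the compounds shown, and "the series" means these compounds.

Compound 1, `CC(=O)c1ccc2c(c1)C(n1ccccc1=O)=CC(C)(C)O2`, is the starting point of this small series. In a functional assay (trachea) with Rattus norvegicus as the target (on this read-out higher numbers stand for higher potency (the scale is a negative logarithm) and lower numbers for lower potency), compound 1 gives 6.65. Compound 2, `CC1(C)C=C(n2ccccc2=O)c2cc(C(=O)c3ccc([N+](=O)[O-])cc3)ccc2O1`, differs from it only at one carbonyl carbon, where a 4-nitrophenyl stands in place of a methyl, and in this assay compound 2 gives 6.09. For the measured compounds named here, that single exchange produced a number 0.56 log units lower from compound 1 to compound 2 (beyond the scatter), so compound 2 stands lower of the two numbers measured so far, with compound 1 as its only neighbour.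

Compound 3, `Cc1ccccc1C(=O)c1ccc2c(c1)C(n1ccccc1=O)=CC(C)(C)O2`, is the next compound to be measured. Compared with compound 2 the change is 2-methylphenyl in place of 4-nitrophenyl on a carbonyl carbon. Going by the values given here, the only measured step that bears on this position is a number 0.56 log units lower from compound 1 to compound 2 (beyond the scatter), and it compares a methyl with an aryl group rather than one aryl group with another, so it offers no direct guide to the size or direction of an aryl-for-aryl swap. An exchange of one six-membered aromatic ring for another at the same carbonyl carbon is expected to move this assay by little, with a slight lean upward given that compound 1 sits higher at 6.65. The step from compound 2 to compound 3 is therefore estimated at a number 0.26 log units higher from compound 2 to compound 3 (within the scatter), and compound 3 is expected to give about 6.35, most likely between 5.85 and 6.85.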

Compound 3, logarithm of the reciprocal of the active concentration, log(1/C): 6.25
Compound 3: middle estimate off by 0.10 log units, on the high side; the range from low to high includes it.
By their numbers in this assay, from the lowest: compounds 2 and 3 (each within the scatter of the next); then compound 1.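

In this assay, exchanging one aryl group for another on a carbonyl carbon gives a number 0.16 log units higher from compound 2 to compound 3 (within the scatter), so 4-nitrophenyl and 2-methylphenyl cannot be told apart here, even though the group that leaves carries a nitro substituent and the group that enters carries only a methyl. For the compounds shown here, putting this second aryl group in place of the methyl gives a number 0.40 log units lower from compound 1 to compound 3 (beyond the scatter), which shows that the lower number seen with 4-nitrophenyl is not confined to that one group: both aryl groups shown sit below the methyl, and no compound here goes against this. Nothing available here accounts for these differences.

The compounds shown place only a methyl and two substituted phenyl rings on this carbonyl carbon, so it remains open how a plain phenyl, a longer chain such as propyl, or a phenyl ring carrying an amine or a carboxylic acid would read. As far as these compounds go, it also remains open whether any group at this place can match or exceed the methyl, or whether the methyl is simply the best of a very small set.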